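The compounds below may be only part of what the source reports. "The series", "measured", "known", "first", "only" and "open" are said of these compounds alone.

Working notes on the series. In a functional assay on MCF7 cells (Homo sapiens) for cytotoxicity, read by MTT assay, with a stated time of 72 h (a lower number here means a stronger inhibitor, a higher number a weaker inhibitor), compound 1 `N[C@H]1CC[C@H](Nc2c(C(=O)NCc3ccc(F)cc3)nc(N3CCCCS3(=O)=O)c3cccnc23)CC1` gives 13000 nM. In this assay compound 3 `N[C@H]1CC[C@H](Nc2c(C(=O)NCc3ccc(Oc4ccccc4)cc3)nc(Br)c3cccnc23)CC1` gives 7900 nM, within the scatter of the number for compound 1, so the two cannot be told apart. Compound 2 `CC(C)(C)OC(=O)N1CCN(c2c(C(=O)NCc3ccc(F)cc3)nc(Br)c3cccnc23)CC1` returns only a limit, > 10000 nM.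

Compound 4 `N[C@H]1CC[C@H](Nc2c(C(=O)NCc3ccc(F)cc3)nc(N3CCCCC3)c3cccnc23)CC1` has not yet been measured. It keeps the shared core of compound 1, with its (4-fluorobenzyl)carbamoyl and (4-aminocyclohexyl)amino groups. Among the measured compounds shown here, the one change is a group of 6 heavy atoms (5 carbon, 1 nitrogen; one six-membered non-aromatic ring with 1 hetero atom) in place of a group of 8 heavy atoms (4 carbon, 1 nitrogen, 2 oxygen, 1 sulfur; one six-membered non-aromatic ring with 2 hetero atoms), on an aromatic carbon. The incoming piperidin-1-yl sits on an aromatic carbon next to the ring nitrogen, para to the (4-aminocyclohexyl)amino group.

For the measured compounds named here, no measured pair isolates this change, so the expectation rests on little. The two numeric readings lie close together, compound 1 at 13000 nM and compound 3 at 7900 nM, and a large move away from them is not expected. The expected change in this assay is a 1.6-fold lower number from compound 1 to compound 4 (0.21 log units; within the scatter), a small step toward a lower number, of a size near the scatter, and its direction is tentative. For compound 4 the estimated value is 8000 nM, with an expected range of 2500 nM to 20000 nM.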

Compound 4, half-maximal inhibitory concentration: 5000 nM
Beside the measured number, compound 4's estimate is 1.6-fold (0.20 log units) above it; low and high end bracket the measured number.
By their numbers in this assay, from the lowest: compounds 4, 3 and 1 (each within the scatter of the next, the first and the last beyond it).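

In this assay, among the compounds shown here, the exchange of the six-membered ring with two hetero atoms for piperidin-1-yl gives the first reading of a single change: a 2.6-fold lower number from compound 1 to compound 4 (0.41 log units; beyond the scatter). The shared core, the (4-fluorobenzyl)carbamoyl group and the (4-aminocyclohexyl)amino group are all held fixed, so the step belongs to this one position, on the aromatic carbon next to the ring nitrogen and para to the (4-aminocyclohexyl)amino group, and shows that the group placed there moves the number beyond the scatter, though only modestly. The values at hand contain no measurement that accounts for this step.

The compounds shown leave open whether the step comes from the ring atoms that differ or from the whole group, and a morpholin-4-yl ring, a pyrrolidin-1-yl ring or an open-chain diethylamino group at this position would help to separate those readings. They also leave open whether the same exchange gives a step of similar size when a 4-phenoxybenzyl group replaces the 4-fluorobenzyl group on the amide.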